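Benzyl for Cyclopentyl on the Purine-Like Core, Untested

The source may hold more compounds than are shown below. What is called first, only, known or untested is meant among the compounds shown, and "the series" means these compounds.

Measured so far:
compound 1 `CC(C)n1cnc2c(NCc3ccc(C(=O)Nc4ccccc4N)cc3)nc(Cl)nc21` — 74.4%
compound 2 `Nc1ccccc1NC(=O)c1ccc(CNc2nc(Cl)nc3c2ncn3C2CCCC2)cc1` — 74.9%

Of the compounds shown here, two have been measured in a functional assay on HepG2 cells (Homo sapiens) for antiproliferative activity, read by CCK-8 assay, with a stated time of 72 h, tested at 8 uM; a lower number here means a weaker effect, a higher number a stronger effect of the compound at the concentration tested. Compound 1 `CC(C)n1cnc2c(NCc3ccc(C(=O)Nc4ccccc4N)cc3)nc(Cl)nc21` gives 74.4%. Compound 2 `Nc1ccccc1NC(=O)c1ccc(CNc2nc(Cl)nc3c2ncn3C2CCCC2)cc1` gives 74.9%. For the measured compounds named here, the one step between them, a number 0.5 percentage points higher from compound 1 to compound 2 (within the scatter), is within the scatter, so compound 2 stands with the higher of the two numbers but is not separated from compound 1 by the measurement.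

Compound 3 `Nc1ccccc1NC(=O)c1ccc(CNc2nc(Cl)nc3c2ncn3Cc2ccccc2)cc1` has not yet been measured. It differs from compound 2 in one place: benzyl in place of cyclopentyl on an aromatic nitrogen.

Going by the values given here, only the step from compound 1 to compound 2 bears on this change, since it also alters the group on the same aromatic nitrogen, and a number 0.5 percentage points higher from compound 1 to compound 2 (within the scatter) shows that exchanging one small saturated group for another there left this assay unchanged within the scatter. Among the compounds with values here, no measured step covers an aromatic group at that position, so the expectation rests on that single comparison alone. Compound 3 is therefore expected to land near compound 2, with the step of a number 2.9 percentage points lower from compound 2 to compound 3 (within the scatter) estimated to stay within the scatter. The estimate for compound 3 in this assay is 72%, with a range from 58% to 84%.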

Compound 3, a percentage reported as inhibition, at one concentration (the size of the read-out at that concentration, not a potency): 5.32%
Compound 3: the middle estimate sits 66.7 percentage points above what was measured; measured number below the stated range.
By their numbers in this assay, from the lowest: compound 3; then compounds 1 and 2 (each within the scatter of the next).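

In this assay, benzyl in place of cyclopentyl on the aromatic nitrogen gives a number 69.6 percentage points lower from compound 2 to compound 3 (beyond the scatter), and benzyl in place of isopropyl at the same nitrogen gives a number 69.1 percentage points lower from compound 1 to compound 3 (beyond the scatter). The earlier pair showed only that cyclopentyl and isopropyl could stand in for each other here, whereas these steps show that the read-out at this position can depend heavily on the group it carries, even though neither cyclopentyl nor benzyl has a hydrogen-bond donor, a hydrogen-bond acceptor or a net charge. No measurement given here accounts for this loss.

The compounds shown leave open whether the loss follows the six-membered aromatic ring itself or the one-carbon link that attaches it, a question that a cyclohexylmethyl or a directly attached phenyl group at this nitrogen would address. They also leave open whether a longer chain such as phenethyl, or a benzyl ring carrying a methoxy group or a fluorine, would behave like benzyl or would instead stand with cyclopentyl and isopropyl.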